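The source may hold more compounds than are shown below. What is called first, only, known or untested is meant among the compounds shown, and "the series" means these compounds.

Working notes on the series. Compound 1 `COc1ccc(-c2nc(C)c(C(=O)CSc3nc(-c4ccc(OC)cc4)c(C#N)c(=O)[nH]3)s2)cc1` is recorded in an ADME assay on HEK293 cells (Homo sapiens) for cytotoxicity, read by MTT assay, with a stated time of 48 h (on this read-out lower numbers stand for stronger inhibition and higher numbers for weaker inhibition), as "not determined" (no result reported); its result there was not reported, so it stands without a value on this read-out. The same holds for compound 3 `COc1ccc(-c2nc(SCC(=O)c3sc(-c4ccc(Cl)cc4)nc3C)[nH]c(=O)c2C#N)cc1`, which in this assay is recorded as "not determined" (no result reported) and also carries no reported result. For the measured compounds named here, the only number in the set comes from compound 2 `Cc1nc(-c2ccccc2)sc1C(=O)CSc1nc(-c2ccccc2)c(C#N)c(=O)[nH]1`, which in this assay gives 93500 nM. Going by the values given here, with no value for compound 1, no step between measured compounds can be drawn from it.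

Compound 4 `COc1ccc(-c2nc(C)c(C(=O)CSc3nc(-c4cccc(OC)c4)c(C#N)c(=O)[nH]3)s2)cc1` is the next entry to be measured in this assay. It differs from compound 1 in one place: 3-methoxyphenyl in place of 4-methoxyphenyl on an aromatic carbon. Because compound 1 has no number, the direction of this step in this assay cannot be read from the data; the expectation is that any effect stays within the usual scatter rather than moving the value by a clear margin, since nothing in the set points one way or the other.

Among the compounds with values here, the estimate for compound 4 in this assay rests on the one reported value: it is expected near the figure of compound 2, 93500 nM, with the range reflecting that compound 2 is the sole anchor. Compound 4 is therefore estimated at 85000 nM, expected to fall between 30000 nM and 200000 nM.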

Compound 4, half-maximal inhibitory concentration: 95400 nM
Compound 4: middle estimate off by 1.1-fold (0.05 log units), on the low side; measured number inside the range.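

In this assay compound 4 gives 95400 nM, but compound 1 has no reported number, so no new step can be read from this pair. The compounds shown leave open whether 3-methoxyphenyl in place of 4-methoxyphenyl shifts the value in this assay at all. No available evidence bears on this result.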